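Shortening a Side Chain: From Compound 3 to Compound 4

The source may hold more compounds than are shown below. What is called first, only, known or untested is meant among the compounds shown, and "the series" means these compounds.

Of the compounds shown here, three have so far been measured in a physicochemical assay for lipophilicity, in phosphate buffer, measured as octanol-water partition; a lower number here means a more polar compound, a higher number a more lipophilic compound. Compound 1 `CCCc1nc2ccccc2c(=O)n1/N=C/c1ccc(Oc2ccc3ccccc3c2)cc1` gives 6.12, compound 2 `Cc1nc2ccccc2c(=O)n1/N=C/c1ccc(Oc2ccc([N+](=O)[O-])cc2)cc1` gives 4.01, and compound 3 `CCCc1nc2ccccc2c(=O)n1/N=C1/C(=O)Nc2ccccc21` gives 3.23. Compound 3 thus stands lowest of the three, with compound 2 nearest at a gap beyond the scatter and compound 1 furthest, also beyond the scatter.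

Compound 4 `Cc1nc2ccccc2c(=O)n1/N=C1/C(=O)Nc2ccccc21` has not yet been measured. It differs from compound 3 in one place: hydrogen in place of ethyl on a saturated chain carbon bound to an aromatic carbon. In this assay a downward step beyond the scatter is expected when the ethyl leaves. The estimated change is a number 0.83 log units lower from compound 3 to compound 4 (beyond the scatter), which would place the new compound below all three measured ones. Compound 4 is therefore estimated at 2.4, with a range from 1.9 to 2.9.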

Compound 4, partition coefficient: 2.23
For compound 4 the middle estimate is 0.17 log units above the measured one; measured number inside the range.
By their numbers in this assay, from the lowest: compound 4; then compound 3; then compound 2; then compound 1.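

For the compounds shown here, this is the first pair here that differs in one place only, so a single change can now be sized: in this assay, hydrogen in place of ethyl on a saturated chain carbon bound to an aromatic carbon gives a number 1.00 log units lower from compound 3 to compound 4 (beyond the scatter) on this shared core. Nothing measured here explains the size of this step.

Going by these compounds, whether the same change gives a similar step on another core stays open, as does what a longer chain, an amine or a carboxylic acid would give at this position.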